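Naphthyl for dimethylphenyl on a urea-linked aniline

The source may hold more compounds than are shown below. What is called first, only, known or untested is meant among the compounds shown, and "the series" means these compounds.

Measured in an assay on isolated protein for inhibition of proto-oncogene tyrosine-protein kinase receptor Ret variant V804L (Homo sapiens), read by 33P incorporation, with stated times of 15 min and 40 min; a lower number here means a stronger inhibitor, a higher number a weaker inhibitor:
compound 1, `O=C(Nc1ccc(Br)cc1)Nc1ccc(Nc2ncnc3c2OCCN3)cc1`, gives > 10000 nM, which is a limit of the assay and not a number.
compound 2, `COc1ccc(NC(=O)Nc2ccc(Nc3ncnc4c3OCCN4)cc2)cc1`, gives 1220 nM.
compound 3, `Cc1cc(C)cc(NC(=O)Nc2ccc(Nc3ncnc4c3OCCN4)cc2)c1`, gives 3770 nM.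

Compound 3 therefore stands highest of the two actual numbers; its nearest neighbour is compound 2, and the step between them is a 3.1-fold higher number from compound 2 to compound 3 (0.49 log units; beyond the scatter). Compound 1 sits at the limit of > 10000 nM in this assay, at which 1 of the 3 values shown sits.

Compound 4, `O=C(Nc1ccc(Nc2ncnc3c2OCCN3)cc1)Nc1cccc2ccccc12`, differs from compound 3 by naphthalen-1-yl in place of 3,5-dimethylphenyl on an amide-type nitrogen. All three measured steps change the same aryl group on that urea nitrogen: an at least 8.1-fold lower number from compound 1 to compound 2 (0.91 log units; beyond the scatter), an at least 2.6-fold lower number from compound 1 to compound 3 (0.42 log units; beyond the scatter) and a 3.1-fold higher number from compound 2 to compound 3 (0.49 log units; beyond the scatter). None of them swaps in a fused two-ring group, so they bear on the new change only by showing that this aryl group can shift the number by modest to at least modest amounts in either direction. Among the compounds with values here, with no closer precedent, the expectation for compound 4 is a step of about a 1.3-fold lower number from compound 3 to compound 4 (0.10 log units; within the scatter) in this assay, which is not clearly beyond the scatter.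

The estimated value for compound 4 is 3000 nM, with a likely range from 700 nM to 12000 nM.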

Compound 4, half-maximal inhibitory concentration: > 10000 nM
Compound 4 gave a limit, no number (the forecaster's own chance of this, stated with the estimate: 20%); middle value at least 3.3-fold (0.52 log units) from the limit.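

In this assay, compound 4 gives > 10000 nM, which is a limit of the assay and not a number. Even so, the change can be read against two neighbours, an at least 2.6-fold higher number from compound 3 to compound 4 (0.42 log units; beyond the scatter) and an at least 8.1-fold higher number from compound 2 to compound 4 (0.91 log units; beyond the scatter), so this fused two-ring group on the urea nitrogen does not keep the activity of either single-ring group it is compared with, although the opening estimate expected little change from compound 3. This shows that adding a second aromatic ring at this position is not a neutral enlargement, and compound 4 now shares with compound 1 a reading that cannot be told apart, so the step between those two cannot be read: the limit of > 10000 nM in this assay, at which 2 of the 4 values shown sit.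

The compounds shown leave open whether the loss comes from the second ring itself or from the way it is attached, a question that naphthalen-2-yl on the same nitrogen would address. They also leave open whether compound 2 at 1220 nM can be bettered by any group here, for example a pyridine ring, or a phenyl ring carrying an amine or a carboxylic acid.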